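Sulfide versus sulfone: a benzyl-for-bromophenyl swap

This account rests on a few compounds, and the source may have more. Where it says the series, first, only, none or still open, it means among the compounds named here.

Compound 1 `O=C(/C(=C\c1c(O)cc(O)cc1O)S(=O)(=O)c1ccc(Br)cc1)c1ccc(Cl)cc1`: in a functional assay on DU-145 cells (Homo sapiens) for inhibition, read by trypan blue exclusion, with a stated time of 96 h (a higher number here means a weaker inhibitor of growth, a lower number a stronger inhibitor of growth), compound 1 gives > 100000 nM, which is a limit of the assay and not a number.
Compound 2 `Cc1ccc(CS(=O)(=O)/C(=C/c2c(O)cc(O)cc2O)C(=O)c2ccc(Cl)cc2)cc1`: in this assay compound 2 gives > 100000 nM, again a limit and not a number.
Compound 3 `O=C(/C(=C\c1ccccc1OCc1ccccc1)Sc1ccc(Br)cc1)c1ccc(Cl)cc1`: in this assay compound 3 gives 10000 nM.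

Compound 1 and compound 2 are related by one change, (4-methylbenzyl in place of 4-bromophenyl on a sulfonyl sulfur). The step that the two limits leave unreadable from compound 1 to compound 2 has no readable size, due to the limit of > 100000 nM in this assay, at which 2 of the 3 values shown sit.

Compound 4 `Cc1ccc(CS/C(=C/c2ccccc2OCc2ccccc2)C(=O)c2ccc(Cl)cc2)cc1` has not yet been measured. It stands to compound 3 as compound 2 stands to compound 1, the change being (4-methylbenzyl in place of 4-bromophenyl on a sulfur). How the core of compound 3 differs from the core of compound 1 is not broken down here. The surroundings of the change also differ: in compound 1 the swap is made on a sulfonyl sulfur whose other neighbours are a double-bonded chain carbon, whereas in compound 3 it is made on a sulfur whose other neighbours are a double-bonded chain carbon. The two swaps are therefore the same kind of change, not the same change.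

Going by the values given here, since the one measured instance of this change yields no size, the expectation for compound 4 rests on compound 3 alone with 10000 nM as the anchor. The step from compound 3 to compound 4 is expected to be small, a 1.2-fold higher number from compound 3 to compound 4 (0.08 log units; within the scatter), with wide uncertainty. Compound 4 is expected to give 12000 nM in this assay, most likely between 3000 nM and 60000 nM.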

Compound 4, concentration for 50% growth inhibition: 1000 nM
For compound 4 the middle estimate is 12-fold (1.08 log units) above the measured one, outside the stated range (below it).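

In this assay, putting 4-methylbenzyl in place of 4-bromophenyl on the sulfur of the core of compound 3 gives a 10-fold lower number from compound 3 to compound 4 (1.00 log units; beyond the scatter), so on this core the swap clearly goes with stronger growth inhibition. This is a single readable instance, and it does not show that the change carries the same way, or to the same extent, onto another core. The matching step on the sulfonyl sulfur cannot be read, because compound 1 and compound 2 both sit at a limit of the assay rather than at a number: the limit of > 100000 nM in this assay, at which 2 of the 4 values shown sit.

The swap also changes more than one feature at once, since the bromine goes, a methyl arrives and a chain carbon now separates the ring from the sulfur, so the compounds shown leave open which of these goes with the stronger inhibition. A plain benzyl, a 4-bromobenzyl or a 4-methylphenyl on the same sulfur would pull these apart, and a longer chain such as 2-phenylethyl would show whether extending the link further continues the trend.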